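A Chlorophenyl Replaces a Methylphenyl on the Ring Nitrogen

The compounds below may be only part of what the source reports. "The series", "measured", "known", "first", "only" and "open" are said of these compounds alone.

Of the compounds shown here, three built on one shared core have been measured in an assay on Sf9 cells for inhibition of protein deacetylase HDAC6 (Homo sapiens), read by fluorescence, with a stated time of 40 min; on this read-out lower numbers stand for stronger inhibition and higher numbers for weaker inhibition. Compound 1 `Cc1ccc(-n2nc(-c3ccccc3)nc2CNc2ccc(C(=O)NO)cc2)cc1` gives 310 nM, the highest number of the three. Compound 3 `O=C(NO)c1ccc(NCc2nc(-c3ccc(Cl)cc3)nn2-c2ccccc2)cc1` gives 181 nM, a difference from compound 1 that falls within the scatter, while compound 2 `COc1ccc(-n2nc(-c3ccc(O)cc3)nc2CNc2ccc(C(=O)NO)cc2)cc1` gives 102 nM, a gap that lies beyond the scatter. Compound 4 `O=C(NO)c1ccc(NCc2nc(-c3ccccc3)nn2-c2ccccc2Cl)cc1` has not yet been measured. It differs from compound 1 in one place: 2-chlorophenyl in place of 4-methylphenyl on an aromatic nitrogen. Among the measured compounds shown here, no measured pair shows this exact change, so the expected step in this assay is small, staying within the scatter, perhaps leaning slightly toward stronger inhibition. Compound 4 is therefore estimated at 220 nM, with a range from 90 nM to 550 nM, which means an expected step of a 1.4-fold lower number from compound 1 to compound 4 (0.15 log units; within the scatter).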

Compound 4, half-maximal inhibitory concentration: 669 nM
Compound 4: middle estimate off by 3.0-fold (0.48 log units), on the low side, outside the stated range (above it).
By their numbers in this assay, from the lowest: compounds 2, 3 and 1 (each within the scatter of the next, the first and the last beyond it); then compound 4.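

In this assay, placing 2-chlorophenyl instead of 4-methylphenyl on the aromatic nitrogen gives a 2.2-fold higher number from compound 1 to compound 4 (0.33 log units; beyond the scatter), so this change weakens inhibition. The two groups hold the same number of heavy atoms and have no hydrogen-bond donors or acceptors, yet the number still moves, showing that this position responds to a swap that leaves those counts unchanged. No measurement at hand explains the step.

Still open, on these data alone, is whether the step follows from the chlorine itself or from where the substituent sits on the phenyl ring. A 2-methylphenyl group on this nitrogen would separate the two.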